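From Methyltetrazole to Methylpyrazole on the Shared Core

A few compounds are considered here, and "the series" means these few. Any claim that something is new, unique, unknown or untested is made for them only; others in the source may bear on it.

Among the compounds with values here, compound 2 `CN1CCC(c2cn(-c3ccc(F)cc3)c3ccc(-c4nnn(C)n4)cc23)CC1` gives 0.28 nM in an in vitro assay on BHK cells for displacement of a labelled ligand from Alpha-1A adrenergic receptor (Bos taurus), read by scintillation counting, with a stated time of 20 min (on this read-out lower numbers stand for stronger inhibition and higher numbers for weaker inhibition), the lowest of the two numbers known. Within the data shown here, compound 1 `CN1CCC(c2cn(-c3ccc(F)cc3)c3ccc(-c4cccnc4)cc23)CC1` gives 2.3 nM, and the change an 8.2-fold lower number from compound 1 to compound 2 (0.91 log units; beyond the scatter) is the only measured step bearing on this series. Compound 3 `CN1CCC(c2cn(-c3ccc(F)cc3)c3ccc(-c4ccn(C)n4)cc23)CC1` differs from compound 2 by 1-methyl-1H-pyrazol-3-yl in place of 2-methyl-2H-tetrazol-5-yl on an aromatic carbon. Among the measured compounds shown here, the only step known swapped a six-membered ring for a five-membered one; here one five-membered ring replaces another, so a smaller step is expected for compound 3, toward a higher number, a 2.1-fold higher number from compound 2 to compound 3 (0.33 log units; beyond the scatter). Compound 3 is therefore estimated at 0.6 nM, within 0.2 nM to 2 nM.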

Compound 3, inhibition constant: 0.54 nM
For compound 3 the middle estimate is 1.1-fold (0.05 log units) above the measured one; the range from low to high includes it.
By their numbers in this assay, from the lowest: compounds 2 and 3 (each within the scatter of the next); then compound 1.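

On this aromatic carbon, 1-methyl-1H-pyrazol-3-yl in place of 2-methyl-2H-tetrazol-5-yl gives a 1.9-fold higher number from compound 2 to compound 3 (0.29 log units; within the scatter), so a five-membered aromatic ring with 2 hetero atoms cannot be told apart from one with 4 hetero atoms. Both five-membered rings stand apart from pyridin-3-yl, since the pyrazole also gives a 4.3-fold lower number from compound 1 to compound 3 (0.63 log units; beyond the scatter). No available evidence accounts for either step. Open, from the compounds shown here alone, is whether the ring methyl matters, as an unsubstituted pyrazole would show, and whether a carboxylic acid or an amide on this carbon would fit the same picture.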